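From 4-bromophenyl to 3-amino-4-methoxyphenyl: working notes

The compounds below may be only part of what the source reports. "The series", "measured", "known", "first", "only" and "open" are said of these compounds alone.

Of the compounds shown here, two have been read so far in a functional assay on MCF7 cells (Homo sapiens) for cytotoxicity, read by MTT assay, with a stated time of 48 h; a lower number here means a stronger inhibitor, a higher number a weaker inhibitor. For compound 1 `COc1cc(NC(=O)n2cc(-c3ccc(O)cc3)n(-c3cc(OC)c(OC)c(OC)c3)c2=O)cc(OC)c1OC` the result is > 50000 nM, which is a limit of the assay and not a number. Among the measured compounds shown here, compound 2 `COc1cc(-n2c(-c3ccc(Br)cc3)cn(C(C)=O)c2=O)cc(OC)c1OC` gives 10600 nM, the only actual number so far.

Compound 3 `COc1ccc(-c2cn(C(C)=O)c(=O)n2-c2cc(OC)c(OC)c(OC)c2)cc1N` is the next to be read. It carries 3-amino-4-methoxyphenyl in place of 4-bromophenyl, on an aromatic carbon of a five-membered aromatic ring with 2 nitrogen (3-amino-4-methoxyphenyl in place of 4-bromophenyl on an aromatic carbon). The acetyl group stays in place.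

For the measured compounds named here, no step between measured compounds is available, so the size of this change has no direct calibration and the range must stay wide. A change toward a stronger inhibitor in this assay, beyond the usual scatter, is expected, starting from compound 2 at 10600 nM. The expected step is a 13-fold lower number from compound 2 to compound 3 (1.12 log units; beyond the scatter). For compound 3 the estimated value is 800 nM, with an expected range of 30 nM to 15000 nM.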

Compound 3, half-maximal inhibitory concentration: 43400 nM
For compound 3 the middle estimate is 54-fold (1.73 log units) below the measured one; measured number above the stated range.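

In this assay, replacing 4-bromophenyl with 3-amino-4-methoxyphenyl, with the acetyl group kept in place, gives a 4.1-fold higher number from compound 2 to compound 3 (0.61 log units; beyond the scatter). Among the compounds shown here, this is the first single-place step: it shows that the aromatic carbon next to the ring nitrogen is not indifferent to the group it carries, and that this exchange, which brings in a hydrogen-bond donor and hydrogen-bond acceptors absent from 4-bromophenyl, goes with a weaker inhibitor. Compound 1 marks the upper end of the readings in this assay with a limit of the assay and not a number, so little room remains for reading further weakening as numbers: the limit of > 50000 nM in this assay, at which 1 of the 3 values shown sits.

The compounds shown leave open which part of the entering group goes with the step, the amine or the methoxy group, and how a plain phenyl or a 4-chlorophenyl would read on this carbon. Also open, from the compounds shown here alone, is whether the same step holds when a propanoyl group stands in place of the acetyl group.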